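Compound 3: A Smaller Group on the Triazole-Free Wording

The source may report more compounds than this note shows. Statements on the series, on what has been measured and on what is new or still open speak of the compounds shown alone.

Swapping a Ring Substituent for a Diol Chain

Measured compounds:
- Compound 1 `O=C1c2c[n+]([O-])c3ccccc3c2C(=O)c2c1c1ccccc1n2CCCCN1CCCCC1`: 200 nM
- Compound 2 `O=C1c2c[n+]([O-])c3ccccc3c2C(=O)c2c1c1ccccc1n2Cc1cn([C@H]2C[C@H](O)[C@@H](CO)O2)nn1`: 120 nM

In a functional assay on HCT-116 cells (Homo sapiens) for cytotoxicity, read by MTT assay, with a stated time of 72 h (on this read-out higher numbers stand for weaker inhibition and lower numbers for stronger inhibition), compound 2, at 120 nM, stands within the usual scatter of compound 1, at 200 nM, so neither compound stands apart on these numbers. Compound 3 `O=C1c2c[n+]([O-])c3ccccc3c2C(=O)c2c1c1ccccc1n2Cc1cn(C[C@@H](O)CO)nn1` has not yet been measured. It keeps the shared core of compound 2 and carries 2,3-dihydroxypropyl in place of 4-hydroxy-5-(hydroxymethyl)oxolan-2-yl on an aromatic nitrogen. Going by the values given here, no measured pair isolates this change, so the data offer no direct guide. Compound 1 at 200 nM and compound 2 at 120 nM carry different side chains, and their values still lie within the scatter, so no step beyond the scatter is expected, in either direction. The expected change is a 1.3-fold higher number from compound 2 to compound 3 (0.10 log units; within the scatter). For compound 3 the estimated value is 150 nM, with an expected range from 60 nM to 380 nM.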

Compound 3, half-maximal inhibitory concentration: 190 nM
Compound 3: middle estimate off by 1.3-fold (0.10 log units), on the low side; measured number inside the range.
By their numbers in this assay, from the lowest: compounds 2, 3 and 1 (each within the scatter of the next).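

In this assay the open 2,3-dihydroxypropyl in place of 4-hydroxy-5-(hydroxymethyl)oxolan-2-yl on an aromatic nitrogen gives a 1.6-fold higher number from compound 2 to compound 3 (0.20 log units; within the scatter) and so shows that, at this position, a group with no ring and 1 defined stereocentre can stand for one with a ring and 3 defined stereocentres without a step beyond the scatter. The larger exchange of 3-(piperidin-1-yl)propyl for a chain ending in 1-(2,3-dihydroxypropyl)-1H-1,2,3-triazol-4-yl gives a 1.1-fold lower number from compound 1 to compound 3 (0.02 log units; within the scatter) and likewise stays within the scatter. Nothing measured here bears on a cause for this result.

In this assay the compounds shown leave open how a carboxylic acid or a primary amine in place of the hydroxyl groups of 2,3-dihydroxypropyl would read. They also leave open whether a longer chain on the same aromatic nitrogen would give a step beyond the scatter.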